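Cytotoxicity series: tetrahydronaphthalenyl replaces methoxyphenyl

The source may hold more compounds than are shown below. What is called first, only, known or untested is meant among the compounds shown, and "the series" means these compounds.

Measured compounds, cytotoxicity in an ADME assay on BJ cells (Homo sapiens) for cytotoxicity, with a stated time of 72 h; a higher number here means that more compound is needed for the effect, a lower number that less compound is needed:
compound 1 `COc1ccc(-c2nc3c(c(C)nn3-c3ccccc3)c(-c3ccccc3O)c2C#N)cc1` sits at a limit of the assay, > 23000 nM.
compound 2 `CCc1ccc(-c2nc3c(c(C)nn3-c3ccccc3)c(-c3ccccc3OC)c2C#N)cc1` sits at a limit of the assay, > 20000 nM.
compound 3 `CCc1ccc(-c2nc3c(c(C)nn3-c3ccccc3)c(-c3ccccc3OC(F)(F)F)c2C#N)cc1` sits at a limit of the assay, > 20000 nM.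

Compound 1 gives no number in this assay, only (the limit of > 23000 nM in this assay, at which 1 of the 3 values shown sits). Compound 2 and compound 3 both stand at the limit of > 20000 nM in this assay, at which 2 of the 3 values shown sit, again without a number. Within the data shown here, the single one-place step measured, a step that the two limits leave unreadable from compound 2 to compound 3, runs from one limit to another and its size cannot be read. The step from compound 1 to compound 4 is therefore not supported by any readable measured step.

Compound 4 `Cc1nn(-c2ccccc2)c2nc(-c3ccc4c(c3)CCCC4)c(C#N)c(-c3ccccc3O)c12` differs from compound 1 by 1,2,3,4-tetrahydronaphthalen-6-yl in place of 4-methoxyphenyl on an aromatic carbon. Across the shared core every measured value lies at a limit, so no direction is known for the exchange of the 4-methoxyphenyl group for the 1,2,3,4-tetrahydronaphthalen-6-yl group on the aromatic carbon.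

The step is expected to be a step that the limit leaves unreadable from compound 1 to compound 4, that is, nothing beyond the scatter, and most probably another limit rather than a number. Compound 4 is expected at 25000 nM, with a range from 8000 nM to 60000 nM.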

Compound 4, half-maximal effective concentration: > 20000 nM
Compound 4 gave a limit, no number; the forecaster's own chance of this, stated with the estimate: 80%; the middle value is on the limit's open side.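

Compound 1 and compound 4 both sit at limits of the assay, and no step can be read between them for the exchange of 4-methoxyphenyl for 1,2,3,4-tetrahydronaphthalen-6-yl. The compounds shown leave open whether any change on the shared core gives a number rather than a limit in this assay, and in which direction this exchange acts.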